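The source may report more compounds than this note shows. Statements on the series, on what has been measured and on what is new or still open speak of the compounds shown alone.

Among the measured compounds shown here, in a functional assay on the whole organism for inhibition, with Rattus norvegicus as the target, read by paw edema, with stated times of 1 h and 3 h (a lower number here means that less compound is needed, a higher number that more compound is needed for the effect), only two related compounds have numbers so far. Compound 1 (`C/C(=N\OCC(=O)O)c1ccc(Br)cc1`) gives 27 mg/kg, and compound 2 (`C/C(=N\OCC(=O)O)c1ccc(Cl)c(Cl)c1`) gives 65 mg/kg. Compound 2 therefore holds the higher of the two numbers, meaning that more of it is needed for the same effect, and its gap to compound 1 lies beyond the usual scatter.

The next compound to be tested, compound 3 (`C/C(=N\OCC(N)=O)c1ccc(Cl)c(Cl)c1`), keeps the structure of compound 2 apart from a single swap: amino in place of hydroxy on a carbonyl carbon. This places amino in place of hydroxy on a carbonyl carbon, so the carboxymethoxy group becomes carbamoylmethoxy.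

For the measured compounds named here, no measured pair shows what this swap does, and compounds 1 and 2 differ elsewhere in their structures, so they offer no direct guide. With no evidence for a direction, the expectation is no shift beyond the scatter. The estimated step is a 1.1-fold lower number from compound 2 to compound 3 (0.03 log units; within the scatter). For compound 3, the expected value in this assay is 60 mg/kg, with an estimated range from 25 mg/kg to 140 mg/kg.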

Compound 3, dose for half-maximal effect: 55 mg/kg
Beside the measured number, compound 3's estimate is 1.1-fold (0.04 log units) above it; the measured number falls inside the stated range.
By their numbers in this assay, from the lowest: compound 1; then compounds 3 and 2 (each within the scatter of the next).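

Among the compounds shown here, this is the first direct reading of what happens when the carboxymethoxy group becomes carbamoylmethoxy: in this assay, amino in place of hydroxy on a carbonyl carbon gives a 1.2-fold lower number from compound 2 to compound 3 (0.07 log units; within the scatter) and so leaves the two compounds indistinguishable in this whole-animal test. On the core shared by this pair, the carboxy group is therefore not required for the effect, and a carbamoyl group at the same place serves equally well at the doses read here. Nothing measured on these compounds explains why the two groups read alike.

The compounds shown leave open whether the same swap would read the same way on the core of compound 1, since that core carries only the carboxymethoxy group here. They also leave open how far this end of the chain tolerates other changes, such as a methyl ester, a nitrile, an amide carrying a methyl group on its nitrogen, or a longer chain between the oxygen and the carbonyl.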